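The compounds below may be only part of what the source reports. "The series", "measured", "known", "first", "only" and "open" are said of these compounds alone.

Measured in a functional assay on J774 cells (Mus musculus) for cytotoxicity, read by resazurin assay; on this read-out lower numbers stand for stronger inhibition and higher numbers for weaker inhibition:
- compound 1 `OCCCCCC(O)c1ccc(-c2ccccc2)cc1`: 22000 nM
- compound 2 `OCCCCCC(O)c1ccc(-c2ccccc2F)cc1`: 22000 nM
- compound 3 `OCCCCCC(O)c1ccc(-c2ccc(Cl)cc2)cc1`: 17000 nM

Compound 3, at 17000 nM, lies within the scatter of both other compounds, so the three values form a single group. Compound 4 `OCCCCCC(O)c1ccc(-c2ccc(Cl)cc2Cl)cc1` differs from compound 3 by one change: chloro in place of hydrogen on an aromatic carbon. This places chloro in place of hydrogen on an aromatic carbon, ortho to a large group and meta to a chloro group. Two measured halogen steps bear on it: a 1.3-fold lower number from compound 1 to compound 3 (0.11 log units; within the scatter) and no change at the digits printed from compound 1 to compound 2 (within the scatter). Neither goes beyond the scatter, so no clear step is expected in this assay. The expected step is a 1.1-fold lower number from compound 3 to compound 4 (0.05 log units; within the scatter). For compound 4 the estimated value is 15000 nM, with an expected range of 8000 nM to 27000 nM.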

Compound 4, half-maximal inhibitory concentration: 8000 nM
The estimate for compound 4 lay 1.9-fold (0.27 log units) above the measured number; the measured number falls inside the stated range.
By their numbers in this assay, from the lowest: compound 4; then compounds 3, 1 and 2 (each within the scatter of the next).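

In this assay chloro in place of hydrogen, ortho to a large group and meta to a chloro group, gives a 2.1-fold lower number from compound 3 to compound 4 (0.33 log units; beyond the scatter) and this modest step is the only one here beyond the scatter. For the compounds shown here, the earlier halogen steps no change at the digits printed from compound 1 to compound 2 (within the scatter) and a 1.3-fold lower number from compound 1 to compound 3 (0.11 log units; within the scatter) stayed inside it, so this second chloro is the first halogen change to move the number clearly. Nothing shown accounts for the step.

The compounds shown leave open whether methoxy or an amine at this place would give a similar step. They also leave open whether chloro here would give this step without the chloro group already present in compound 3.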